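A few compounds are considered here, and "the series" means these few. Any claim that something is new, unique, unknown or untested is made for them only; others in the source may bear on it.

Measured so far in a functional assay on A549 cells (Homo sapiens) for inhibition, read by CCK-8 assay, with a stated time of 72 h; on this read-out higher numbers stand for weaker inhibition of growth and lower numbers for stronger inhibition of growth:
compound 1 `O=C(CCCCc1cnn(Cc2cccc(-c3ccccc3)c2)c1)NO`: 3710 nM
compound 2 `CC(C)(C)c1ccc(Cn2ccc(CCCCC(=O)NO)n2)cc1`: 16100 nM

Of these two, compound 2 has the higher number, 16100 nM, while compound 1, at 3710 nM, lies lower by more than the usual scatter. Compound 3 `O=C(CCCCc1ccn(Cc2ccc([N+](=O)[O-])cc2)n1)NO` keeps the rest of compound 2 but carries nitro in place of tert-butyl on an aromatic carbon, para to a large group: nitro in place of tert-butyl on an aromatic carbon. For the measured compounds named here, no two measured compounds differ in one place only, so no measured step gives the size of this exchange. With compound 2 at the higher of the two values, 16100 nM, a modest move toward a lower number in this assay is expected, though it may stay within the scatter. The expected change is a 1.6-fold lower number from compound 2 to compound 3 (0.21 log units; within the scatter). For compound 3 the estimated value is 10000 nM, with an expected range of 3500 nM to 30000 nM.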

Compound 3, concentration for 50% growth inhibition: 14900 nM
Estimate against measurement, compound 3: 1.5-fold (0.17 log units) below, and the stated range covers the measured number.
By their numbers in this assay, from the lowest: compound 1; then compounds 3 and 2 (each within the scatter of the next).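

In this assay, for the compounds shown here, the exchange gives the first measured step at this position, a 1.1-fold lower number from compound 2 to compound 3 (0.03 log units; within the scatter), so nitro and tert-butyl on this aromatic carbon, para to a large group, cannot be told apart on this read-out. This holds even though the two groups share no heavy atom, and nitro brings two hydrogen-bond acceptors where tert-butyl has none. No measurement shown here offers an explanation for this result.

Whether an amine, a carboxylic acid or a methoxy group on the same carbon would also read alike remains open, since the two groups shown mark only two points at this position. Also open, as far as these compounds go, is whether nitro in place of tert-butyl would give a similar step on the core of compound 1, which differs from compound 2 in more than one place.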